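The source may hold more compounds than are shown below. What is called first, only, known or untested is meant among the compounds shown, and "the series" means these compounds.

Series of quaternary ammonium butyrates, examined in an assay for inhibition of gamma-butyrobetaine dioxygenase (Homo sapiens), read by HPLC, with stated times of 15 min and 30 min; on this read-out lower numbers stand for stronger inhibition and higher numbers for weaker inhibition.

Compound 1 `C[N+](C)(CCCC(=O)[O-])CC1CC1` carries a cyclopropylmethyl group on the nitrogen. In this assay compound 1 returns only a limit of the assay, > 1000000 nM. Compound 2 `CCC[N+](C)(C)CCCC(=O)[O-]` differs by ethyl in place of cyclopropyl on a saturated chain carbon bound to an amine nitrogen. In this assay compound 2 likewise returns only a limit, > 1000000 nM. The step that the two limits leave unreadable from compound 1 to compound 2 is therefore not readable, since both values sit at the limit of > 1000000 nM in this assay, at which 2 of the 2 values shown sit. Compound 2 thus stands at the edge of what the assay reports, with no measured inhibition to rank it among real numbers.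

Compound 3 `CC(C)[N+](C)(C)CCCC(=O)[O-]` is the next member: isopropyl in place of propyl on an amine nitrogen, the two compounds holding the same atoms joined differently. Within the data shown here, no measured step bears directly on this change; the only step in hand, a step that the two limits leave unreadable from compound 1 to compound 2, gives no size because its two values rest at the limit of > 1000000 nM in this assay, at which 2 of the 2 values shown sit. Nothing in the series points to a readable gain in this assay. Compound 3 is expected to give 2000000 nM in this assay, with a range of 500000 nM to 8000000 nM, most probably reported again as a limit. The estimate implies a step that the limit leaves unreadable from compound 2 to compound 3, expected to lie within the scatter.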

Compound 3, half-maximal inhibitory concentration: 5700 nM
The estimate for compound 3 lay 350-fold (2.55 log units) above the measured number; measured number below the stated range.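

In this assay, isopropyl in place of propyl on the amine nitrogen is the first change shown to yield a measured number rather than a limit, with an at least 170-fold lower number from compound 2 to compound 3 (2.24 log units; beyond the scatter), although the two groups hold the same atoms joined differently. Isopropyl in place of cyclopropylmethyl at the same nitrogen gives an at least 170-fold lower number from compound 1 to compound 3 (2.24 log units; beyond the scatter), whereas the step between the other two compounds cannot be read. At this position, therefore, how the three carbons of the group are joined can separate a measurable inhibitor from an unreadable compound, and both step sizes are lower bounds only, as each starts from a limit: the limit of > 1000000 nM in this assay, at which 2 of the 3 values shown sit.

The compounds shown leave open whether the drop in the number is particular to isopropyl or extends to other groups on the amine nitrogen, such as tert-butyl or cyclopentyl. They also leave open whether compound 3 keeps its number with a longer chain leading to the carboxylic acid, or with a sulfonic acid in place of the carboxylic acid.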